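Swapping one small aromatic ring for another on a polyol-bearing core

A few compounds are considered here, and "the series" means these few. Any claim that something is new, unique, unknown or untested is made for them only; others in the source may bear on it.

Three compounds sharing a sugar-like chain attached to a small five-membered aromatic core have been measured in an ADME assay on the whole organism (strain 129/SvEvBrd x C57BL/6) for metabolic stability, with Mus musculus as the target; on this read-out higher numbers stand for a longer-lived compound and lower numbers for a shorter-lived compound. Compound 1 `CC(O)c1nc([C@@H](O)[C@H](O)[C@H](O)CO)c[nH]1` gives 4.4 h. Compound 2 `Cc1nc(-c2nc([C@@H](O)[C@H](O)[C@H](O)CO)c[nH]2)cs1` gives 2.1 h. Compound 3 `OC[C@@H](O)[C@@H](O)[C@H](O)c1c[nH]c(-c2cocn2)n1` gives 1.2 h, the lowest of the three numbers; the step of a 3.7-fold lower number from compound 1 to compound 3 (0.56 log units; beyond the scatter) lies beyond the scatter, while the step of a 1.8-fold lower number from compound 2 to compound 3 (0.24 log units; within the scatter) does not.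

Compound 4 `OC[C@@H](O)[C@@H](O)[C@H](O)c1c[nH]c(-c2cnccn2)n1` has not yet been measured. It differs from compound 3 in one place: pyrazin-2-yl in place of 1,3-oxazol-4-yl on an aromatic carbon. Within the data shown here, the only measured step that exchanges one aromatic ring for another at this position, a 1.8-fold lower number from compound 2 to compound 3 (0.24 log units; within the scatter), stayed within the scatter. The two larger steps, a 2.1-fold lower number from compound 1 to compound 2 (0.32 log units; beyond the scatter) and a 3.7-fold lower number from compound 1 to compound 3 (0.56 log units; beyond the scatter), replace a 1-hydroxyethyl group rather than a ring, so they speak less directly to this change. No step beyond the scatter is therefore expected in this assay, in either direction.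

The expected step is a 1.1-fold higher number from compound 3 to compound 4 (0.03 log units; within the scatter). Compound 4 is estimated at 1.3 h, within a range from 0.65 h to 2.6 h.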

Compound 4, half-life: 1.9 h
For compound 4 the middle estimate is 1.5-fold (0.16 log units) below the measured one; measured number inside the range.
By their numbers in this assay, from the lowest: compounds 3, 4 and 2 (each within the scatter of the next); then compound 1.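

Compound 4 shows that this position accepts a six-membered aromatic ring as well as a five-membered one with no change that can be told from scatter in this assay: both a 1.6-fold higher number from compound 3 to compound 4 (0.20 log units; within the scatter) and a 1.1-fold lower number from compound 2 to compound 4 (0.04 log units; within the scatter) stay within it. The three ring-bearing compounds therefore cannot be ordered on this read-out, whichever ring they carry. By contrast, a 2.3-fold lower number from compound 1 to compound 4 (0.36 log units; beyond the scatter) lies beyond the scatter, so compound 1, with its 1-hydroxyethyl group, now stands apart from all three ring-bearing compounds, though no measurement at hand explains this.

Still open, on these data alone, is whether the separation follows from having a ring at this place or from the 1-hydroxyethyl group itself. An ethyl chain, an amine or a carboxylic acid here could help to settle that.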